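A few compounds are considered here, and "the series" means these few. Any claim that something is new, unique, unknown or untested is made for them only; others in the source may bear on it.

In an ADME assay on L1210/0 cells (Mus musculus) for cytotoxicity, with a stated time of 48 h (a lower number here means a stronger inhibitor, a higher number a weaker inhibitor), three compounds have been measured:

Compound 1 `OCCOCn1cnc2c(S)nc(F)nc21`: 170000 nM
Compound 2 `CC(=O)OCCOCn1cnc2c(S)nc(F)nc21`: 40000 nM
Compound 3 `CC(O)Cn1cnc2c(N)nc(I)nc21`: > 200000 nM

The value of compound 3 in this assay is a limit of the assay, not a number. Within the data shown here, the only one-place comparison among the measured compounds is a 4.3-fold lower number from compound 1 to compound 2 (0.63 log units; beyond the scatter), the change being (acetyl in place of hydrogen on an oxygen on a saturated carbon). Compound 3 is built on a different core from compound 1, and the difference between the two cores is not broken down here.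

Compound 4 `CC(=O)OC(C)Cn1cnc2c(N)nc(I)nc21` has not yet been measured. It stands to compound 3 as compound 2 stands to compound 1: acetyl in place of hydrogen on an oxygen on a saturated carbon, at a place described in the same words in both pairs, so this is the same change. The step from compound 3 to compound 4 is therefore expected to resemble the earlier one, and compound 4 is estimated to show an at least 1.3-fold lower number from compound 3 to compound 4 (0.12 log units; that floor lies within the scatter) because a 4.3-fold lower number from compound 1 to compound 2 (0.63 log units; beyond the scatter) was seen with this change. Because compound 3 sits at the limit of > 200000 nM in this assay, at which 1 of the 3 values shown sits, the measurement for compound 4 may again return only a limit. Compound 4 is expected to give about 150000 nM, plausibly between 50000 nM and 400000 nM.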

Compound 4, half-maximal inhibitory concentration: > 200000 nM
Compound 4: a limit, no number; the forecaster's own chance of this, stated with the estimate: 45%; middle value at least 1.3-fold (0.12 log units) from the limit.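

In this assay compound 4 gives > 200000 nM, which is a limit and not a number. Compound 3 also carries a limit, so no step between compound 3 and compound 4 can be read: the limit of > 200000 nM in this assay, at which 2 of the 4 values shown sit.

The compounds shown leave open whether acetyl in place of hydrogen changes the number on the core of compound 3 as it does on the core of compound 1.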